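The compounds below may be only part of what the source reports. "The series", "measured", "known", "first", "only" and "open" are said of these compounds alone.

For the measured compounds named here, compound 3 `CN(c1ccc(NC(=O)c2ccccc2)cc1OCc1ccccc1)S(C)(=O)=O` is one of three compounds measured in an assay on SK-BR-3 cells for inhibition of Aromatase (Homo sapiens); a lower number here means a stronger inhibitor, a higher number a weaker inhibitor: compound 3 gives 1770 nM, compound 1 `O=[N+]([O-])c1ccc(S(=O)(=O)Nc2ccc([N+](=O)[O-])cc2OCc2ccccc2)cc1` gives 2170 nM, and compound 2 `CN(c1ccc(N)cc1OCc1ccccc1)S(C)(=O)=O` gives 1100 nM. Compound 3 stands second highest of the three numbers, yet all three lie within the scatter of one another. Compound 4 `CN(c1ccc(NC(=O)C2CCCCC2)cc1OCc1ccccc1)S(C)(=O)=O` differs from compound 3 in one place: cyclohexyl in place of phenyl on a carbonyl carbon. Going by the values given here, the only measured step, a 1.6-fold higher number from compound 2 to compound 3 (0.21 log units; within the scatter), concerns a different change, and no measured pair shows cyclohexyl in place of phenyl on a carbonyl carbon, so nothing measured bears directly on this step. The expected step of a 1.0-fold higher number from compound 3 to compound 4 (0.01 log units; within the scatter) is therefore none beyond the scatter. Compound 4 is estimated at 1800 nM, within 700 nM to 4500 nM.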

Compound 4, half-maximal inhibitory concentration: 250 nM
Estimate against measurement, compound 4: 7.2-fold (0.86 log units) above; measured number below the stated range.
By their numbers in this assay, from the lowest: compound 4; then compounds 2, 3 and 1 (each within the scatter of the next).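

Cyclohexyl in place of phenyl on the carbonyl carbon gives a 7.1-fold lower number from compound 3 to compound 4 (0.85 log units; beyond the scatter), so the ring held on this carbonyl matters, which the earlier compounds had not shown. Acylating the nitrogen is not enough in itself: cyclohexylcarbonyl in place of hydrogen gives a 4.4-fold lower number from compound 2 to compound 4 (0.64 log units; beyond the scatter), whereas benzoyl there gives only a 1.6-fold higher number from compound 2 to compound 3 (0.21 log units; within the scatter), within the scatter. Nothing measured here explains why the two rings differ.

From the compounds shown here alone, whether a cyclopentyl ring or an open chain such as n-hexyl on the same carbonyl would match cyclohexyl remains open, as does a piperidine ring there.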